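The compounds below may be only part of what the source reports. "The series", "measured", "known", "first", "only" and "open" are said of these compounds alone.

Measured so far in a functional assay on MCF7 cells (Homo sapiens) for antiproliferative activity, read by MTT assay, with a stated time of 72 h; a higher number here means a weaker inhibitor, a lower number a stronger inhibitor:
compound 1 `C/C=C1/[C@H](O[C@@H]2O[C@H](COC(C)=O)[C@@H](OC(C)=O)[C@H](OC(C)=O)[C@H]2OC(C)=O)OC=C(C(=O)OC)[C@H]1CC(=O)OCCCCCCCCCCCCCCC` gives 9660 nM
compound 2 `C/C=C1/[C@H](O[C@@H]2O[C@H](CO)[C@@H](O)[C@H](O)[C@H]2O)OC=C(C(=O)OC)[C@H]1CC(=O)OCCC1CCCCC1` gives 5000 nM
compound 3 `C/C=C1/[C@H](O[C@@H]2O[C@H](COC(C)=O)[C@@H](OC(C)=O)[C@H](OC(C)=O)[C@H]2OC(C)=O)OC=C(C(=O)OC)[C@H]1CC(=O)OCCC` gives 15000 nM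

Compound 2 at 5000 nM lies within the scatter of compound 1, so no order can be drawn between those two. Its number is lower than that of compound 3, and that gap lies beyond the scatter.

The next compound in the series is compound 4 `C/C=C1/[C@H](O[C@@H]2O[C@H](CO)[C@@H](O)[C@H](O)[C@H]2O)OC=C(C(=O)OC)[C@H]1CC(=O)OCCc1ccccc1`, not yet measured. It differs from compound 2 by a single change (phenyl in place of cyclohexyl on a saturated chain carbon, two bonds along the chain from an oxygen next to a carbonyl group): phenyl in place of cyclohexyl on a saturated chain carbon, two bonds along the chain from an oxygen next to a carbonyl group.

Among the measured compounds shown here, only one measured step is available (a 1.6-fold higher number from compound 1 to compound 3 (0.19 log units; within the scatter)), and it lies within the scatter. For the measured compounds named here, that step exchanges no ring, and no measured pair shows cyclohexyl giving way to phenyl, so it is only a loose guide. It does show that a large change of chain left the number within the scatter.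

The expected step (a 1.1-fold higher number from compound 2 to compound 4 (0.04 log units; within the scatter)) is estimated to stay within the scatter, with no firm direction. For compound 4 the expected value is 5500 nM (estimated range 2200 nM to 14000 nM).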

Compound 4, half-maximal inhibitory concentration: 19300 nM
For compound 4 the middle estimate is 3.5-fold (0.55 log units) below the measured one, outside the stated range (above it).
By their numbers in this assay, from the lowest: compounds 2, 1, 3 and 4 (each within the scatter of the next, the first and the last beyond it).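

In this assay, the exchange of cyclohexyl for phenyl on a saturated chain carbon, two bonds along the chain from an oxygen next to a carbonyl group, gives a 3.9-fold higher number from compound 2 to compound 4 (0.59 log units; beyond the scatter) and so shows that this end of the ester chain does respond to a change of group. Among the compounds shown here, the only earlier step here, a 1.6-fold higher number from compound 1 to compound 3 (0.19 log units; within the scatter), stayed within the scatter despite the loss of dodecyl, whereas this exchange passes beyond the scatter with the heavy-atom count unchanged, the two groups differing as a six-membered non-aromatic and a six-membered aromatic ring of carbon only. Nothing measured in the series accounts for this gap.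

From the compounds shown here alone, whether the gap persists with a longer chain carrying the phenyl, or with a phenyl bearing an amine or a carboxylic acid, stays open. It is also open whether the same exchange gives a step of similar size with the acetyl groups present in compound 1 and compound 3, since the step shown rests on a single pair with free hydroxyl groups.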